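This account rests on a few compounds, and the source may have more. Where it says the series, first, only, none or still open, it means among the compounds named here.

Compound 3 `O=C1/C(=C\c2ccccc2[N+](=O)[O-])c2ccccc2N1c1c(Cl)cccc1Cl` gives 10 ug/mL in a functional assay on L132 cells (Homo sapiens) for cytotoxicity, read by MTT assay, with a stated time of 72 h (on this read-out higher numbers stand for an effect only at larger amounts of compound and lower numbers for an effect already at smaller amounts), the lowest of the three numbers measured. Its nearest neighbour is compound 2 `O=C1/C(=C\c2cccc(Oc3ccccc3)c2)c2ccccc2N1c1c(Cl)cccc1Cl` with 24 ug/mL, and furthest away stands compound 1 `O=C1/C(=C\c2ccc(O)cc2)c2ccccc2N1c1c(Cl)cccc1Cl` with 30 ug/mL, both beyond the scatter. Compound 4 `O=C1/C(=C\c2cccc(Cl)c2)c2ccccc2N1c1c(Cl)cccc1Cl` differs from compound 3 in one place: 3-chlorophenyl in place of 2-nitrophenyl on a double-bonded chain carbon bound to a double-bonded ring carbon. Among the compounds with values here, only one measured step changes this same group, a 3.0-fold lower number from compound 1 to compound 3 (0.48 log units; beyond the scatter), a modest shift. Within the data shown here, no measured pair involves 3-chlorophenyl, so the direction for compound 4 is open; the exchanges seen so far moved this assay only modestly. Among the measured compounds shown here, compound 4 is therefore expected to land a little higher, near the earlier compounds, giving an estimated 2.0-fold higher number from compound 3 to compound 4 (0.30 log units; within the scatter). The estimate for compound 4 is 20 ug/mL, within a range from 8 ug/mL to 45 ug/mL.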

Compound 4, concentration for half-maximal effect: 16 ug/mL
For compound 4 the middle estimate is 1.3-fold (0.10 log units) above the measured one, within the range that was stated.
By their numbers in this assay, from the lowest: compounds 3, 4, 2 and 1 (each within the scatter of the next, the first and the last beyond it).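

In this assay, 3-chlorophenyl in place of 2-nitrophenyl gives a 1.6-fold higher number from compound 3 to compound 4 (0.20 log units; within the scatter), so removing the nitro-bearing ring at this place need not shift the number beyond the scatter. Chloro in place of phenoxy gives a 1.5-fold lower number from compound 2 to compound 4 (0.18 log units; within the scatter) and 3-chlorophenyl in place of 4-hydroxyphenyl gives a 1.9-fold lower number from compound 1 to compound 4 (0.27 log units; within the scatter), placing compound 4 within the scatter of all three earlier compounds, even though compound 1 and compound 3 differ beyond it. No measurement here explains these small steps. Going by these compounds, how an aminophenyl or carboxyphenyl group, or a longer chain, would behave at this place remains open.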